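This account rests on a few compounds, and the source may have more. Where it says the series, first, only, none or still open, it means among the compounds named here.

Three compounds that share one core have numbers in a functional assay (plasma) with Oryctolagus cuniculus as the target; a higher number here means a weaker inhibitor, a lower number a stronger inhibitor. Compound 1 `Cc1nc2cnccc2n1CC1CCN(C(=O)CCc2ccccc2)CC1` gives 60 nM, compound 2 `Cc1nc2cnccc2n1CC1CCN(C(=O)CC(O)(c2ccccc2)C(F)(F)F)CC1` gives 36 nM, and compound 3 `Cc1nc2cnccc2n1CC1CCN(C(=O)N[C@H](C)c2ccccc2)CC1` gives 13 nM. That last number is the lowest of the three, and its gaps to the other two lie beyond the scatter.

The next compound to be tested, compound 4 `CCOC(=O)[C@H](CC(C)C)NC(=O)N1CCC(Cn2c(C)nc3cnccc32)CC1`, keeps the shared core and the carbonyl with its amide-type nitrogen. It differs from compound 3 in one place, with 1-(ethoxycarbonyl)-3-methylbutyl in place of 1-phenylethyl on that nitrogen: 1-(ethoxycarbonyl)-3-methylbutyl in place of 1-phenylethyl on an amide-type nitrogen. The six-membered aromatic ring of carbon leaves, and no ring enters.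

Among the measured compounds shown here, only one measured step bears on this, and only in part: a 4.6-fold lower number from compound 1 to compound 3 (0.66 log units; beyond the scatter). That modest step brought in the (1-phenylethyl)amino group, and compound 4 keeps only the amide-type nitrogen of that group. All three measured compounds carry an aromatic ring of carbon in this part of the molecule, so the data do not show what losing it does.

The expectation is therefore a small move towards a higher number, probably within the scatter, and the estimated step is a 1.5-fold higher number from compound 3 to compound 4 (0.19 log units; within the scatter). For compound 4 the estimated value is 20 nM, with an expected range from 5 nM to 80 nM.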

Compound 4, half-maximal inhibitory concentration: 12 nM
For compound 4 the middle estimate is 1.7-fold (0.22 log units) above the measured one; measured number inside the range.
By their numbers in this assay, from the lowest: compounds 4 and 3 (each within the scatter of the next); then compounds 2 and 1 (each within the scatter of the next).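

In this assay the exchange of 1-phenylethyl for 1-(ethoxycarbonyl)-3-methylbutyl on the amide-type nitrogen gives a 1.1-fold lower number from compound 3 to compound 4 (0.03 log units; within the scatter), so the two compounds cannot be told apart in this test. Among the compounds shown here, this is the first information on losing the six-membered aromatic ring of carbon from this part of the molecule: compound 4 has no ring in the entering group, yet its number stays within the scatter of that of compound 3, so at least this one ring-free group can take the place of 1-phenylethyl here. No measurement shown gives any reason for this match between two such different groups.

Compound 4 removes the ring and brings in the ethoxycarbonyl group in a single change, so the compounds shown do not reveal what each of these contributes alone. Open questions include how a plain 3-methylbutyl chain without the ethoxycarbonyl group would behave on that nitrogen, and whether a carboxylic acid in place of the ethyl ester, or the opposite arrangement at the stereocentre, would keep the number where it is.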